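The source may report more compounds than this note shows. Statements on the series, on what has been measured and on what is new or still open speak of the compounds shown alone.

Compound 1 `O=C(O)c1cccc(C2=C(c3cc(Br)ccc3OCc3ccc(Cl)cc3)CCC2)c1` gives 0.4 L/kg in an in vivo ADME assay on the whole organism for pharmacokinetics, with Rattus norvegicus as the target, at a dose of 1 mg/kg by the intravenous route; on this read-out higher numbers stand for wider distribution into tissues and lower numbers for narrower distribution.
Compound 2 `O=C(O)c1cccc(C2=C(c3cc(Br)ccc3OCc3ccc(F)cc3F)CCC2)c1` gives 0.6 L/kg in this assay.
Compound 3 `O=C(O)c1cccc(C2=C(c3cc(Cl)ccc3OCc3ccccc3)CCC2)c1` gives 0.8 L/kg in this assay.

All three numbers sit within the usual scatter of one another, so compound 3 cannot be set apart from compound 1 or compound 2 on this read-out. Compound 4 `O=C(O)c1cccc(C2=C(c3cc(Br)ccc3OCc3ccccc3)CCC2)c1` differs from compound 3 by bromo in place of chloro on an aromatic carbon. Within the data shown here, the only measured single step, a 1.5-fold higher number from compound 1 to compound 2 (0.18 log units; within the scatter), concerns a different part of the molecule and stayed within the scatter; no measured step swaps one halogen for another on the aromatic ring. Nothing here points to a shift beyond the scatter, so compound 4 is expected to sit close to compound 3, with a 1.1-fold lower number from compound 3 to compound 4 (0.06 log units; within the scatter). The estimate for compound 4 in this assay is 0.7 L/kg, between 0.4 L/kg and 1.3 L/kg.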

Compound 4, volume of distribution at steady state: 1 L/kg
Compound 4: middle estimate off by 1.4-fold (0.15 log units), on the low side; the range from low to high includes it.
By their numbers in this assay, from the lowest: compounds 1, 2, 3 and 4 (each within the scatter of the next, the first and the last beyond it).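

At the aromatic carbon para to a benzyloxy group, this assay cannot separate bromo from chloro, with a 1.3-fold higher number from compound 3 to compound 4 (0.10 log units; within the scatter) as the step. Phenyl in place of 2,4-difluorophenyl also stays within the scatter, with a 1.7-fold higher number from compound 2 to compound 4 (0.22 log units; within the scatter) as the step. Hydrogen in place of chloro on the other aromatic ring gives a 2.5-fold higher number from compound 1 to compound 4 (0.40 log units; beyond the scatter) and is the only step here beyond the scatter, though only modestly.

On these data alone, whether a methoxy or a nitrile at the bromo position would stay in the same range remains open. No measurement offered here explains any of these steps.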